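A few compounds are considered here, and "the series" means these few. Any claim that something is new, unique, unknown or untested is made for them only; others in the source may bear on it.

Compound 1 `Fc1ccc2c(c1)c(OCCn1ccnc1)nn2-c1ccccc1F` and compound 2 `O=C1NCCN1CCOc1nn(-c2ccc(F)cc2)c2ccc(F)cc12` were measured in an ADME assay on the whole organism (strain Sprague-Dawley) for pharmacokinetics, with Rattus norvegicus as the target, read by LC-MS; on this read-out higher numbers stand for higher oral bioavailability and lower numbers for lower oral bioavailability. In this assay compound 1 gives 28%, the lowest of the two numbers. Compound 2 gives 54%, a number that lies beyond the scatter above compound 1. Compound 3 `O=c1[nH]ccn1CCOc1nn(-c2ccccc2F)c2ccc(F)cc12` has not yet been measured. It differs from compound 1 in one place: a group of 6 heavy atoms (3 carbon, 2 nitrogen, 1 oxygen; one five-membered aromatic ring with 2 hetero atoms) in place of a group of 5 heavy atoms (3 carbon, 2 nitrogen; one five-membered aromatic ring with 2 hetero atoms), on a saturated chain carbon, two bonds along the chain from an oxygen on an aromatic ring. Going by the values given here, no measured pair shows this change, so its effect is not known from the data. The entering group brings one hydrogen-bond donor, which compound 2 also carries. A modest rise is expected, a number 12 percentage points higher from compound 1 to compound 3 (beyond the scatter). Compound 3 is estimated at 40%, within 20% to 60%.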

Compound 3, oral bioavailability: 35%
For compound 3 the middle estimate is 5 percentage points above the measured one, within the range that was stated.
By their numbers in this assay, from the lowest: compounds 1 and 3 (each within the scatter of the next); then compound 2.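

Going by these compounds alone, at this place on the saturated chain carbon, the first measured change of the ring gives a number 7 percentage points higher from compound 1 to compound 3 (within the scatter) in this assay. The entering ring thus brings a hydrogen-bond donor and a double bond outside the aromatic ring, yet the step stays within the usual scatter, so this change is not shown to alter oral bioavailability. Nothing measured here offers an explanation for this result.

Still open, from the compounds shown here alone, is how a morpholine, a carboxylic acid or a dimethylamino group would behave at this place. Also open, going by these compounds, is what a longer chain carrying the same ring would give.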